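The source may hold more compounds than are shown below. What is called first, only, known or untested is meant among the compounds shown, and "the series" means these compounds.

Measured so far:
compound 1, `COC1=CC(=O)c2c(c(COC(=O)c3ccc(F)cc3)c(C)n2C)C1=O`, 27000 nM in a functional assay on V79-379A cells (Cricetulus griseus) for cytotoxicity, read by MTT assay, in the presence of a further agent that is not named here; a lower number here means a stronger inhibitor, a higher number a weaker inhibitor;
compound 2, `COC1=CC(=O)c2c(c(COCc3ccccc3)c(C)n2C)C1=O`, 225000 nM.

Compound 2 stands at the highest number of the two, with compound 1 at a lower one, and the gap between them lies beyond the scatter. Among the measured compounds shown here, no pair of measured compounds differs in just one place, so no single step can be read from these two. Compound 3, `COC1=CC(=O)c2c(c(COc3ccc(F)cc3)c(C)n2C)C1=O`, is not yet measured. It differs from compound 2 in one place: 4-fluorophenyl in place of benzyl on an oxygen on a saturated carbon. For the measured compounds named here, with no measured step of this kind to lean on, the direction can only be judged loosely; the expectation is a move to a somewhat lower number, a step of a 3.2-fold lower number from compound 2 to compound 3 (0.51 log units; beyond the scatter), though a result within the scatter would not surprise. Compound 3 is accordingly estimated at 70000 nM, within a range from 15000 nM to 300000 nM.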

Compound 3, half-maximal inhibitory concentration: 31000 nM
For compound 3 the middle estimate is 2.3-fold (0.35 log units) above the measured one; low and high end bracket the measured number.
By their numbers in this assay, from the lowest: compounds 1 and 3 (each within the scatter of the next); then compound 2.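

Among the compounds shown here, this position responds to the group on the oxygen: in this assay the change from benzyl to 4-fluorophenyl gives a 7.3-fold lower number from compound 2 to compound 3 (0.86 log units; beyond the scatter) and is the only single change that can be read here. The two groups have the same count of heavy atoms and each holds one six-membered aromatic ring of carbon only, so the step appears without any change in those counts. Nothing measured bears on what lies behind the step.

The step joins two changes, the loss of the saturated carbon of benzyl and the entry of fluorine, and separating them would take plain phenyl or 4-fluorobenzyl on this oxygen. As far as these compounds go, how an amine or a longer chain on the same oxygen would read in this assay also stays open.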